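Ester-to-acid step on the thioether chain

The source may hold more compounds than are shown below. What is called first, only, known or untested is meant among the compounds shown, and "the series" means these compounds.

Going by the values given here, compound 2 `CCCCC1([C@H](O)/C=C/C2CCC(=O)[C@@H]2CCCCCCC(=O)OCC)CCC1` gives 0.409 mg/kg in a functional assay on the whole organism (strain Hartley) for inhibition, with Cavia porcellus as the target, with stated times of 15 min and 2 min (on this read-out higher numbers stand for an effect only at larger amounts of compound and lower numbers for an effect already at smaller amounts), and this is the highest of the two numbers so far; its nearest neighbour is compound 1 `CCCCC1([C@H](O)/C=C/C2CCC(=O)[C@@H]2CCCCSCC(=O)OCC)CCC1`, which in this assay gives 0.3 mg/kg. Among the compounds with values here, the one measured step, a 1.4-fold higher number from compound 1 to compound 2 (0.13 log units; within the scatter), concerns the exchange of the thioether-containing chain end for the all-carbon chain end and lies within the scatter.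

Compound 3 `CCCCC1([C@H](O)/C=C/C2CCC(=O)[C@@H]2CCCCSCC(=O)O)CCC1` is to be measured in this assay. It differs from compound 2 by (carboxymethyl)sulfanyl in place of 2-(ethoxycarbonyl)ethyl on a saturated chain carbon, four bonds along the chain from a saturated ring carbon. This change combines two things: the return to the thioether chain already seen in compound 1, and the loss of the ethyl of the ester, leaving the free acid. Only the first part is covered by a measured step, a 1.4-fold higher number from compound 1 to compound 2 (0.13 log units; within the scatter), which is within the scatter. Within the data shown here, no measured pair differs by ester to acid alone, so that part of the change is uncovered by the numbers. The expectation for compound 3 therefore rests on compound 1 with added uncertainty: a step of a 1.2-fold lower number from compound 2 to compound 3 (0.07 log units; within the scatter) is expected, which would leave compound 3 within the scatter of both measured compounds. The estimate for compound 3 in this assay is 0.35 mg/kg, with a range from 0.08 mg/kg to 1.5 mg/kg.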

Compound 3, dose for half-maximal effect: 0.171 mg/kg
For compound 3 the middle estimate is 2.0-fold (0.31 log units) above the measured one; measured number inside the range.
By their numbers in this assay, from the lowest: compounds 3, 1 and 2 (each within the scatter of the next, the first and the last beyond it).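

In this assay, going by these compounds alone, the combined change of chain end and ester gives the first step beyond the scatter: a 2.4-fold lower number from compound 2 to compound 3 (0.38 log units; beyond the scatter), with (carboxymethyl)sulfanyl in place of 2-(ethoxycarbonyl)ethyl. The ester-to-acid exchange on the thioether chain can now be read alone, as hydrogen in place of ethyl on an oxygen next to a carbonyl group, and a 1.8-fold lower number from compound 1 to compound 3 (0.24 log units; within the scatter) leaves the free acid and its ethyl ester indistinguishable on this read-out. At this position, therefore, neither the thioether-to-all-carbon exchange nor the ester-to-acid exchange separates two compounds when measured alone, only the two together do, and nothing measured here offers an explanation for the result.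

Open, from the compounds shown here alone, is whether the ester-to-acid exchange reads the same on the all-carbon chain, which would need that chain ending in a carboxylic acid. Also open, going by these compounds, is how a primary amide or a tetrazole at the chain end, or a longer chain in place of (carboxymethyl)sulfanyl, would read in this assay.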